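The source may hold more compounds than are shown below. What is called first, only, known or untested is meant among the compounds shown, and "the series" means these compounds.

For the measured compounds named here, in an ADME assay on liver for metabolic stability, with Liver microsome (Homo sapiens) as the target, read by LC-MS, using microsomes (on this read-out lower numbers stand for slow clearance and higher numbers for fast clearance), compound 3 (`CC(C)(C)[C@@H](O)C(=O)N1[C@H](C(=O)NCc2cc(Cl)ccc2-n2cnnn2)C[C@@H]2C[C@@H]21`) gives 75 mL.min-1.g-1 and lies within the scatter of compound 2 (`CC(C)(C)[C@@H](O)C(=O)N1[C@@H]2C[C@@H]2C[C@H]1C(=O)NCc1cc(Cl)ccc1-n1cnnn1`) at 54 mL.min-1.g-1 and of compound 1 (`O=C(NCc1cc(Cl)ccc1-n1cnnn1)[C@@H]1C[C@@H]2C[C@@H]2N1C(=O)[C@H](O)C1CCCCC1`) at 150 mL.min-1.g-1 on the numbers so far. Compound 4 (`O=C(NCc1cc(Cl)ccc1-n1cnnn1)[C@@H]1C[C@@H]2C[C@@H]2N1C(=O)[C@H](O)Cc1ccccn1`) has (pyridin-2-yl)methyl in place of tert-butyl on a saturated chain carbon bound to a carbonyl carbon and an oxygen on a saturated carbon. Going by the values given here, the only measured change at that place, cyclohexyl to tert-butyl, stayed small (a 2.0-fold lower number from compound 1 to compound 3 (0.30 log units; within the scatter)), as did the configuration-only step (a 1.4-fold higher number from compound 2 to compound 3 (0.14 log units; within the scatter)). Among the compounds with values here, no measured compound carries (pyridin-2-yl)methyl, so no step beyond the scatter is expected in this assay here. The estimated move is small (a 1.3-fold lower number from compound 3 to compound 4 (0.10 log units; within the scatter)). For compound 4 the expected value is 60 mL.min-1.g-1 with 25 mL.min-1.g-1 to 140 mL.min-1.g-1 as its estimated range.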

Compound 4, intrinsic clearance in microsomes: 17 mL.min-1.g-1
Compound 4: the middle estimate sits 3.5-fold (0.55 log units) above what was measured; measured number below the stated range.
By their numbers in this assay, from the lowest: compound 4; then compounds 2, 3 and 1 (each within the scatter of the next, the first and the last beyond it).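

In this assay, the place on the saturated chain carbon proves able to move the clearance number beyond the scatter: (pyridin-2-yl)methyl for tert-butyl gives a 4.4-fold lower number from compound 3 to compound 4 (0.64 log units; beyond the scatter), whereas cyclohexyl to tert-butyl stayed within it. The same group for cyclohexyl gives an 8.8-fold lower number from compound 1 to compound 4 (0.95 log units; beyond the scatter), so it reads lower than both saturated groups shown. No available evidence accounts for the size of these steps. Still open, from the compounds shown here alone, is whether the ring nitrogen matters: benzyl at this place would separate it from the ring itself.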